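A dimethylmorpholine in place of benzyl(methyl)amino

The compounds below may be only part of what the source reports. "The series", "measured", "known", "first", "only" and "open" are said of these compounds alone.

Measured so far in a physicochemical assay for acid dissociation:
- compound 1 `Cc1csc2cc([C@H](C)Nc3ncnc(N)c3C#N)c(-c3cccc(CN(C)CCCCN(C)Cc4ccccc4)c3)c(=O)n12`: 9.1
- compound 2 `Cc1csc2cc([C@H](C)Nc3ncnc(N)c3C#N)c(-c3cccc(CN4CCC(CN(C)CC(C)C)CC4)c3)c(=O)n12`: 9.8
- compound 3 `Cc1csc2cc([C@H](C)Nc3ncnc(N)c3C#N)c(-c3cccc(CN4CCC(CN(C)Cc5ccccn5)CC4)c3)c(=O)n12`: 9

In this assay, compound 1 at 9.1 and compound 3 at 9 lie within the scatter of each other, while compound 2 at 9.8 stands beyond the scatter above both. Compound 4 `Cc1csc2cc([C@H](C)Nc3ncnc(N)c3C#N)c(-c3cccc(CN(C)CCCCN4C[C@@H](C)O[C@@H](C)C4)c3)c(=O)n12` has yet to be measured. Compared with compound 1, it carries 2,6-dimethylmorpholin-4-yl in place of benzyl(methyl)amino on a saturated chain carbon, four bonds along the chain from an amine nitrogen.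

Within the data shown here, only one measured step bears on this, and only loosely: a number 0.80 log units lower from compound 2 to compound 3 (beyond the scatter), with pyridin-2-yl in place of isopropyl on a saturated chain carbon bound to an amine nitrogen. That exchange involves different groups at a different place, so it offers a direction and an upper guide to size, not a close precedent. A smaller step in the same direction is expected here. The estimated step is a number 0.30 log units lower from compound 1 to compound 4 (within the scatter). The expected value for compound 4 is 8.8, with an estimated range from 8.3 to 9.3.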

Compound 4, acid dissociation constant: 8.9
Compound 4: the middle estimate sits 0.10 log units below what was measured, and the stated range covers the measured number.
By their numbers in this assay, from the lowest: compounds 4, 3 and 1 (each within the scatter of the next); then compound 2.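

In this assay, placing 2,6-dimethylmorpholin-4-yl in place of benzyl(methyl)amino on a saturated chain carbon, four bonds along the chain from an amine nitrogen, gives a number 0.20 log units lower from compound 1 to compound 4 (within the scatter). At this position, then, a six-membered non-aromatic ring with 2 hetero atoms can replace a group holding a six-membered aromatic ring of carbon only without taking the number beyond the scatter, unlike the exchange at a different place that gave a number 0.80 log units lower from compound 2 to compound 3 (beyond the scatter). Nothing measured here accounts for this result.

The compounds shown leave open whether a piperidine, a dimethylamino group or a carboxylic acid in place of benzyl(methyl)amino would also stay within the scatter of compound 1. They also do not show which nitrogen of compound 4 the number belongs to, or whether another stereoisomer of 2,6-dimethylmorpholin-4-yl would read the same.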